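A few compounds are considered here, and "the series" means these few. Any claim that something is new, unique, unknown or untested is made for them only; others in the source may bear on it.

Values so far in a functional assay for inhibition, with Homo sapiens as the target (a higher number here means a weaker inhibitor, a lower number a stronger inhibitor), are:
- compound 1 (`COC(=O)[C@@H](CC1CCCCC1)Nc1nc2ccccc2o1`) gives 100 nM
- compound 2 (`COc1ccc(C(CC2CCCCC2)Nc2nc3ccccc3o2)cc1`) gives 550 nM
- compound 3 (`CC(C)c1ccc2oc(NC(CC3CCCCC3)c3ccccc3)nc2c1`) gives 6 nM

Compound 3 has the lowest number of the three and lies beyond the scatter from both compound 1 and compound 2. Compound 4 (`CC(=O)Nc1ccc2oc(NC(CC3CCCCC3)c3ccccc3)nc2c1`) has acetamido in place of isopropyl on an aromatic carbon. Among the compounds with values here, no measured pair isolates this change, so the expectation is only a judgement. Since compound 3 at 6 nM sits at the low end of the series, a change here seems more likely to raise the number than to lower it. An upward step beyond the scatter is expected, estimated as a 10-fold higher number from compound 3 to compound 4 (1.00 log units; beyond the scatter) in this assay for now. Compound 4 is estimated at 60 nM with an expected range from 12 nM to 300 nM at this stage.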

Compound 4, half-maximal inhibitory concentration: 78 nM
The estimate for compound 4 lay 1.3-fold (0.11 log units) below the measured number; low and high end bracket the measured number.
By their numbers in this assay, from the lowest: compound 3; then compounds 4 and 1 (each within the scatter of the next); then compound 2.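

In this assay, within the data shown here, this is the first pair that differs in one place: acetamido in place of isopropyl on this aromatic carbon gives a 13-fold higher number from compound 3 to compound 4 (1.11 log units; beyond the scatter) and so shows that the position is sensitive to its substituent. Of these two groups, isopropyl gives the lower number. No available evidence bears on the reason for this step. Still open, as far as these compounds go, is how other groups at this carbon would compare, such as an amine, a methoxy group or a carboxylic acid. Also open, from the compounds shown here alone, is whether a longer alkyl chain would keep the number of compound 3 at 6 nM or change it.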